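Chloro in place of methoxy: working notes on compound 3

The source may report more compounds than this note shows. Statements on the series, on what has been measured and on what is new or still open speak of the compounds shown alone.

Measured so far in a functional assay on HCT-116 cells (Homo sapiens) for antiproliferative activity, read by MTT assay, with a stated time of 72 h; a higher number here means a weaker inhibitor, a lower number a stronger inhibitor 
compound 1 `COc1ccc(NC(=S)Nc2nc(C(=O)NCc3ccccc3)cs2)cc1` gives 18200 nM 
compound 2 `COc1ccc(NC(=S)Nc2nc(C(=O)NCCCc3ccccc3)cs2)cc1` gives 44800 nM 

Compound 1 at 18200 nM stands lowest of the two measured compounds in this assay and compound 2 is its nearest neighbour. Compound 3 `O=C(NCc1ccccc1)c1csc(NC(=S)Nc2ccc(Cl)cc2)n1` has chloro in place of methoxy on an aromatic carbon and keeps the rest of compound 1 unchanged. Among the measured compounds shown here, the one measured step of a 2.5-fold higher number from compound 1 to compound 2 (0.39 log units; beyond the scatter) is modest and lies on the saturated chain, so no measured step covers this swap. It offers only a rough guide to the size of change in this series. The estimated step of a 1.3-fold lower number from compound 1 to compound 3 (0.11 log units; within the scatter) is expected to stay within the scatter, with no clear direction. Compound 3 is expected at 14000 nM with an estimated range from 5000 nM to 40000 nM in this assay.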

Compound 3, half-maximal inhibitory concentration: 62200 nM
Estimate against measurement, compound 3: 4.4-fold (0.65 log units) below; the whole stated range lies below it.
By their numbers in this assay, from the lowest: compound 1; then compounds 2 and 3 (each within the scatter of the next).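

In this assay, among the compounds shown here, the only measured change on the aromatic ring, chloro in place of methoxy, gives a 3.4-fold higher number from compound 1 to compound 3 (0.53 log units; beyond the scatter) and shows that the series responds to the group at this position, not only to the saturated chain. Compound 1, with methoxy, remains the strongest inhibitor of the three. No available evidence accounts for this step. Open, from the compounds shown here alone, is how other groups at this position, such as fluoro, methyl or dimethylamino, would compare with methoxy and chloro. Also open, going by these compounds, is whether the same step would hold on the longer chain of compound 2.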